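From hexyl to pyrrolidin-2-yl: what to expect for compound 3

The source may hold more compounds than are shown below. What is called first, only, known or untested is meant among the compounds shown, and "the series" means these compounds.

Measured so far in a functional assay, read by fluorescence and spectrophotometry, with a stated time of 1 h; on this read-out lower numbers stand for an effect already at smaller amounts and higher numbers for an effect only at larger amounts of compound:
Compound 1, `CCCCCCCS(=O)(=O)/C=C/c1ccc(O)c(O)c1`, gives 7100 nM.
Compound 2, `CCCCCCCCCCCCS(=O)(=O)/C=C/c1ccc(O)c(O)c1`, gives 8500 nM.

Among these two numbers compound 1 stands lowest, but the step of a 1.2-fold higher number from compound 1 to compound 2 (0.08 log units; within the scatter) is within the scatter, so the two compounds cannot be told apart in this assay. Going by the values given here, that single step is the only comparison available, and it concerns a longer or shorter chain on the same sulfonyl-bearing carbon.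

Compound 3, `O=S(=O)(/C=C/c1ccc(O)c(O)c1)CC1CCCN1`, is not yet measured. It differs from compound 1 as follows: pyrrolidin-2-yl in place of hexyl on a saturated chain carbon bound to a sulfonyl sulfur. Among the compounds with values here, no measured step replaces a chain with a ring that carries a hydrogen-bond donor and acceptor, so the one step in hand bears on this change only loosely: it shows that changing the chain on this carbon did not move the number beyond the scatter.

On that basis the expectation for compound 3 is a number close to that of compound 1, with an estimated step of a 1.4-fold higher number from compound 1 to compound 3 (0.15 log units; within the scatter). The estimate for compound 3 is 10000 nM, within an expected range from 3000 nM to 35000 nM.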

Compound 3, half-maximal effective concentration: 13800 nM
Compound 3: the middle estimate sits 1.4-fold (0.14 log units) below what was measured; measured number inside the range.
By their numbers in this assay, from the lowest: compounds 1, 2 and 3 (each within the scatter of the next).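

In this assay, replacing hexyl with pyrrolidin-2-yl on a saturated chain carbon bound to a sulfonyl sulfur gives a 1.9-fold higher number from compound 1 to compound 3 (0.29 log units; within the scatter). The earlier pair differed only in the length of an all-carbon chain, whereas this change brings in a nitrogen, a five-membered non-aromatic ring, a hydrogen-bond donor and a hydrogen-bond acceptor, and the two compounds still cannot be told apart in this read-out. So at this place, a change in the kind of group, and not just in chain length, has so far left the number within the usual scatter, although no measurement available here helps to explain this result.

All the groups shown at this place leave the numbers within the scatter of the next, so it remains open whether any group there can shift the number clearly in either direction. A much shorter chain such as methyl, or a carboxylic acid carried on the same carbon, would test that question, as would a simple cyclopentyl ring, which would separate the effect of the ring from that of the nitrogen.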